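From an Ester to an Acid on a Shared Core

The source may hold more compounds than are shown below. What is called first, only, known or untested is meant among the compounds shown, and "the series" means these compounds.

Of the compounds shown here, two of a shared core have been measured in a functional assay on BV-2 cells (Mus musculus, strain C57BL6/J) for inhibition, read by Griess assay, with a stated time of 24 h; on this read-out lower numbers stand for stronger inhibition and higher numbers for weaker inhibition. Compound 1 has the structure `COC(=O)CC1=CC[C@H]2[C@H](C[C@@H]1C)OC(=O)[C@H]2C`. In this assay compound 1 gives > 10000 nM, which is a limit of the assay and not a number. Compound 2, with the structure `C[C@H]1C[C@@H]2OC(=O)[C@H](C)[C@H]2C=CC1=O`, gives in this assay > 10000 nM, again a limit rather than a number. Compound 1 therefore stands where every value shown stands: the limit of > 10000 nM in this assay, at which 2 of the 2 values shown sit, so no ordering between the two measured compounds can be read. Compound 3, with the structure `C[C@@H]1C(=O)O[C@H]2C[C@H](C)C(C(=O)O)=CC[C@@H]21`, has not yet been measured in this assay. It differs from compound 1 in one place: carboxy in place of (methoxycarbonyl)methyl on a double-bonded ring carbon. No step between measured compounds is shown, and both values shown are limits, so the data give no direction for carboxy in place of (methoxycarbonyl)methyl. The estimated step, a step that the limit leaves unreadable from compound 1 to compound 3, is therefore expected to be none beyond the scatter, with another limit the most likely outcome. Compound 3 is estimated at 15000 nM, within a range from 5000 nM to 50000 nM.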

Compound 3, half-maximal inhibitory concentration: > 10000 nM
Compound 3: a limit, no number; the forecaster's own chance of this, stated with the estimate: 85%; the middle value does not contradict the limit.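

No step can be read from compound 1 to compound 3, since the values of both are limits and not numbers: the limit of > 10000 nM in this assay, at which 3 of the 3 values shown sit. The compounds shown leave open whether any change on the shared core can give a measurable inhibition, and how carboxy truly compares with (methoxycarbonyl)methyl on the double-bonded ring carbon.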